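This account rests on a few compounds, and the source may have more. Where it says the series, first, only, none or still open, it means among the compounds named here.

For the measured compounds named here, in a functional assay on A549 cells (Homo sapiens) for inhibition, read by colorimetric assay and MTT assay, with a stated time of 72 h (on this read-out lower numbers stand for stronger inhibition and higher numbers for weaker inhibition), compound 1 (`C=CCCCCCOc1ncc(-c2ccccc2OCCCCC=C)n1C`) gives 62000 nM, the only numerical value available so far. Compound 2 (`Cn1c(-c2ccccc2O)cnc1S(=O)(=O)c1ccccc1`) returns a limit, > 100000 nM. The next compound, compound 3 (`C=CCCCCOc1ccccc1-c1cnc(NC(=O)CCCC=C)n1C`), keeps the core of compound 1 and changes one group: ((pent-4-en-1-yl)carbonyl)amino in place of (hept-6-en-1-yl)oxy on an aromatic carbon, between two ring nitrogen atoms (((pent-4-en-1-yl)carbonyl)amino in place of (hept-6-en-1-yl)oxy on an aromatic carbon). Going by the values given here, no measured pair of compounds shows what a change of this kind does, so the only anchor is compound 1 at 62000 nM. On that basis, no shift beyond the scatter is expected in this assay. The expected change is a 1.4-fold lower number from compound 1 to compound 3 (0.14 log units; within the scatter). Compound 3 is estimated at 45000 nM, with an expected range from 15000 nM to 100000 nM.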

Compound 3, half-maximal inhibitory concentration: 8000 nM
Beside the measured number, compound 3's estimate is 5.6-fold (0.75 log units) above it, outside the stated range (below it).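

The exchange of (hept-6-en-1-yl)oxy for ((pent-4-en-1-yl)carbonyl)amino on an aromatic carbon, between two ring nitrogen atoms, gives a 7.8-fold lower number from compound 1 to compound 3 (0.89 log units; beyond the scatter) in this assay, so the read-out responds to the group at this position. The two groups have the same number of heavy atoms and neither carries a ring, whereas the entering group has a hydrogen-bond donor and the leaving group has none. Nothing measured here bears on why this change lowers the number.

This single step does not separate the part played by the amide hydrogen from that of the carbonyl or the chain. Going by these compounds, it remains open how a simple amine at this position, or a longer chain on the carbonyl, would read in this assay, and whether the alkene at the chain end matters.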